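Methoxy shift on the thiophene: compound 2 to compound 3

The compounds below may be only part of what the source reports. "The series", "measured", "known", "first", "only" and "open" are said of these compounds alone.

Values so far in a functional assay on MES-SA cells (Homo sapiens) for antiproliferative activity, read by resazurin assay, with a stated time of 72 h; a higher number here means a weaker inhibitor, a lower number a stronger inhibitor
- Compound 1 (`COc1cc(/C=C\c2cccs2)cc(OC)c1OC`) gives ("not determined" (no result reported))
- Compound 2 (`COc1ccc(/C=C\c2cc(OC)c(OC)c(OC)c2)s1`) gives (53 nM)

Going by the values given here, compound 2 holds the only number, so it has no rank yet. Compound 3 (`COc1csc(/C=C\c2cc(OC)c(OC)c(OC)c2)c1`) differs from it by one change, (4-methoxythiophen-2-yl in place of 5-methoxythiophen-2-yl on a double-bonded chain carbon bound to a double-bonded chain carbon), with the same atoms joined differently. Among the compounds with values here, no measured pair shows what such a change does in this assay, so any expectation is loose. A moderate loss of inhibition is expected. The estimated size is a 1.9-fold higher number from compound 2 to compound 3 (0.28 log units; within the scatter) toward weaker inhibition, with wide uncertainty. For compound 3 the expected value is 100 nM in an estimated range of 25 nM to 500 nM as the likely span.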

Compound 3, half-maximal inhibitory concentration: 25 nM
Estimate against measurement, compound 3: 4.0-fold (0.60 log units) above; low and high end bracket the measured number.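

In this assay, going by these compounds alone, 4-methoxythiophen-2-yl in place of 5-methoxythiophen-2-yl gives a 2.1-fold lower number from compound 2 to compound 3 (0.33 log units; beyond the scatter) and provides the first readable pair. With the same atoms joined differently, the methoxy placement on the thiophene alone separates the two values, modestly but beyond the scatter, toward stronger inhibition. Nothing at hand accounts for this difference.

Compound 1 stands at "not determined" (no result reported) and so gives no reference for the thiophene without methoxy. From the compounds shown here alone, whether an ethoxy group or an amine in place of methoxy would keep this activity remains open.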